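The source may report more compounds than this note shows. Statements on the series, on what has been measured and on what is new or still open speak of the compounds shown alone.

Compound 1 `Cc1cc(O)c(C(=O)/C=C/c2ccc(F)cc2)c(-c2ccc(OCc3ccccc3)cc2)c1C(=O)/C=C/c1ccc(F)cc1`, measured in an ADME assay on HEK293 cells (Homo sapiens) for cytotoxicity, read by MTT assay, with a stated time of 24 h (on this read-out lower numbers stand for stronger inhibition and higher numbers for weaker inhibition), gives 30000 nM. Compound 2 `COc1ccc(/C=C/C(=O)c2c(C)cc(O)c(C(=O)/C=C/c3ccc(OC)cc3)c2-c2ccc(Br)cc2)cc1` was tested in the same way, but no number came out of it: in this assay compound 2 was reported as "not active" (no number reported), so it stands without a value to compare. Compound 3 `COc1ccc(/C=C/C(=O)c2c(C)cc(O)c(C(=O)/C=C/c3ccc(OC)cc3)c2-c2ccccc2)cc1` differs from compound 2 in a single spot, (hydrogen in place of bromo on an aromatic carbon). For the measured compounds named here, no measured pair here shows such a change, so nothing beyond the usual scatter is expected in this assay. Compound 3 is expected to give about 40000 nM, somewhere between 15000 nM and 100000 nM.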

Compound 3, half-maximal inhibitory concentration: "not active" (no number reported)
For compound 3 the study gives words and no number, and the estimate cannot be compared.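

In this assay compound 2 and compound 3 were both reported as not active, without a number, so no step can be read between them. On these data alone, what the change from 4-bromophenyl to phenyl does to this read-out stays open. Nothing shown here bears on a cause.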